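Hydrazone-urea thiazole series: L02 cytotoxicity notes

The compounds below may be only part of what the source reports. "The series", "measured", "known", "first", "only" and "open" are said of these compounds alone.

Measured so far:
- compound 1 `CN(C(=O)NC(=O)c1ccc(F)c(F)c1)c1nc(C(F)(F)F)c(C(=O)N/N=C/c2ccc(C(F)(F)F)cc2)s1`: 13.2 ug/mL
- compound 2 `CN(C(=O)NC(=O)c1cccc(C(F)(F)F)c1)c1nc(C(F)(F)F)c(C(=O)N/N=C/c2ccc(C(F)(F)F)cc2)s1`: "not determined" (no result reported)
- compound 3 `CN(C(=O)NC(=O)c1ccc(C(F)(F)F)cc1)c1nc(C(F)(F)F)c(C(=O)N/N=C/c2ccc(C(F)(F)F)cc2)s1`: "not determined" (no result reported)

Within the data shown here, in an ADME assay on L02 cells (Homo sapiens) for inhibition, read by MTT assay, with a stated time of 72 h (on this read-out higher numbers stand for weaker inhibition and lower numbers for stronger inhibition), compound 1 gives 13.2 ug/mL, the only number in the set. For compound 2 and compound 3 no result is reported in this assay, so compound 1 stands alone without a comparator.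

Compound 4 `CN(C(=O)NC(=O)c1ccc(F)c(F)c1)c1nc(C(F)(F)F)c(C(=O)N/N=C/c2cccc(C(F)(F)F)c2)s1` keeps the shared core of compound 1 and differs only in 3-(trifluoromethyl)phenyl in place of 4-(trifluoromethyl)phenyl on a carbon with a double bond to nitrogen. Among the measured compounds shown here, with no measured pair to calibrate such a change, the expected step from compound 1 to compound 4 is a 1.0-fold lower number from compound 1 to compound 4 (0.01 log units; within the scatter), which is estimated to stay within the usual scatter and in no particular direction. Compound 4 is therefore expected to give about 13 ug/mL in this assay, with a range from 6 ug/mL to 28 ug/mL.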

Compound 4, half-maximal inhibitory concentration: 23.5 ug/mL
The estimate for compound 4 lay 1.8-fold (0.26 log units) below the measured number; measured number inside the range.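

In this assay, among these compounds, 3-(trifluoromethyl)phenyl in place of 4-(trifluoromethyl)phenyl on a carbon with a double bond to nitrogen gives a 1.8-fold higher number from compound 1 to compound 4 (0.25 log units; within the scatter), the first step that can be read. This step stays within the usual scatter, so the two arrangements of the trifluoromethyl group cannot be told apart on this read-out. No measurement shown here bears on the reason for the result.

Still open, going by these compounds, is whether an amine or a carboxylic acid on this phenyl ring would shift the number beyond the scatter.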